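A bulkier terminal amide and its expected cytotoxicity

This account rests on a few compounds, and the source may have more. Where it says the series, first, only, none or still open, it means among the compounds named here.

The three measured compounds share one core and differ at the amide end. Compound 1 `CC(C)C[C@H](NC(=O)[C@]1(Cc2ccccc2)CCN1C(=O)OCc1ccccc1)C(N)=O` carries a 1-carbamoyl-3-methylbutyl group on the amide-type nitrogen; in an ADME assay on HELF cells (Homo sapiens) for cytotoxicity, with a stated time of 3 days (on this read-out lower numbers stand for higher toxicity in this test and higher numbers for lower toxicity in this test), compound 1 gives 100000 nM. Compound 3 `C[C@H](NC(=O)[C@]1(Cc2ccccc2)CCN1C(=O)OCc1ccccc1)C(=O)N(C)C` carries a 1-(dimethylcarbamoyl)ethyl group there instead. In this assay compound 3 reaches only a limit of the test, > 100000 nM. Compound 2 `C[C@H](NC(=O)[C@@]1(Cc2ccccc2)CCN1C(=O)OCc1ccccc1)C(=O)N(C)C` has the same atoms and bonds as compound 3 and differs only in configuration as drawn. In this assay compound 2 likewise stands at a limit, > 100000 nM, so no number is known for it. Within the data shown here, the step of a number no lower from compound 1 to compound 3 (the limit leaves the size open) and the step that the two limits leave unreadable from compound 2 to compound 3 are both open in size because of the limit of > 100000 nM in this assay, at which 2 of the 3 values shown sit, and the second is a pure stereochemical comparison because of the fact that compounds 2 and 3 differ only in the configuration as drawn; none of the measured steps gives a readable size.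

Compound 4 `CC(C)CNC(=O)[C@H](C)NC(=O)[C@@]1(Cc2ccccc2)CCN1C(=O)OCc1ccccc1` differs from compound 2 by isobutylamino in place of dimethylamino on a carbonyl carbon. Among the measured compounds shown here, no measured step bears directly on this change, since the only amide-end change, from compound 1 to compound 3, could not be sized. As every value shown sits at or above the same level, compound 4 is expected to stay there as well, with an expected step of a number no higher from compound 2 to compound 4 (the limit leaves the size open). For compound 4 the estimate in this assay is 100000 nM, within 50000 nM to 200000 nM, most likely again reported only as a limit.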

Compound 4, minimum cytotoxic concentration: > 100000 nM
Compound 4 gave a limit, no number; the forecaster's own chance of this, stated with the estimate: 70%; the middle value lies on the limit itself.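

In this assay compound 4 gives > 100000 nM, a limit and not a number. With compound 2 also at a limit, no step can be read between compound 2 and compound 4: the limit of > 100000 nM in this assay, at which 3 of the 4 values shown sit.

The compounds shown leave open the actual values of compounds 2, 3 and 4, and so what isobutylamino in place of dimethylamino on a carbonyl carbon does to the read-out.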